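The source may report more compounds than this note shows. Statements on the series, on what has been measured and on what is new or still open speak of the compounds shown alone.

Of the compounds shown here, two have been measured in an ADME assay on microsomes from liver (Rattus norvegicus) for metabolic stability, read by LC-MS, using NADPH; a higher number here means that the compound lasts longer, a lower number that the compound disappears faster. Compound 2 (`O=C(NCCCCN1CCN(c2ccccc2C(F)(F)F)CC1)c1ccc(-c2ccsc2)cc1`) gives 0.0667 h, and compound 1 (`O=C(NCCCCN1CCN(c2cccc(O)c2)CC1)c1ccc(-c2ccsc2)cc1`) gives 0.085 h; the change from a 1.3-fold lower number from compound 1 to compound 2 (0.11 log units; within the scatter) lies within the scatter, so the two cannot be told apart. Compound 3 (`O=C(NCCCCN1CCN(c2cccc(C(F)(F)F)c2)CC1)c1ccc(-c2ccsc2)cc1`) carries 3-(trifluoromethyl)phenyl in place of 2-(trifluoromethyl)phenyl on an amine nitrogen in a ring. Going by the values given here, no measured step moves a trifluoromethyl around the phenyl ring, and the one step at hand, from a 1.3-fold lower number from compound 1 to compound 2 (0.11 log units; within the scatter), was itself within the scatter, so no step beyond the scatter is expected: a 1.0-fold higher number from compound 2 to compound 3 (0.02 log units; within the scatter). Compound 3 is therefore estimated at 0.07 h, with a range from 0.03 h to 0.16 h.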

Compound 3, half-life: 0.282 h
Estimate against measurement, compound 3: 4.0-fold (0.61 log units) below; the measured number lies above the stated range.
By their numbers in this assay, from the lowest: compounds 2 and 1 (each within the scatter of the next); then compound 3.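

In this assay the place of the trifluoromethyl on the phenyl ring counts: the same atoms joined differently give a 4.2-fold higher number from compound 2 to compound 3 (0.63 log units; beyond the scatter) where the earlier pair showed nothing beyond the scatter. With the group at this place, trifluoromethyl in place of hydroxy also gives a readable change, a 3.3-fold higher number from compound 1 to compound 3 (0.52 log units; beyond the scatter) and so the choice of group counts here too. No measurement at hand explains either step. On these data alone, whether a nitrile or a chlorine in place of the trifluoromethyl in 3-(trifluoromethyl)phenyl would keep the higher number remains open. So does whether a longer chain would shift it.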